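Nitrile in place of two chlorines on the benzyl

The compounds below may be only part of what the source reports. "The series", "measured", "known", "first", "only" and "open" are said of these compounds alone.

Among the measured compounds shown here, in a functional assay on HEK293 cells for agonist activity at G-protein coupled receptor 39 (Homo sapiens), read by scintillation proximity assay and inositol phosphate accumulation, with a stated time of 75 min (on this read-out lower numbers stand for an effect already at smaller amounts and higher numbers for an effect only at larger amounts of compound), compound 2 `Cc1nn(-c2ncnc3nc[nH]c23)c2c1C(OCc1ccc(Cl)cc1Cl)CC(=O)N2` gives 243 nM, the lower of the two numbers known so far, while compound 1 `Cc1nn(-c2ncnc3nc[nH]c23)c2c1C(OCC(=O)c1ccc(F)cc1)CC(=O)N2` gives 973 nM. For the measured compounds named here, the only step on record, a 4.0-fold lower number from compound 1 to compound 2 (0.60 log units; beyond the scatter), concerns the same place but a different exchange, so no measured step bears directly on the change to compound 3 `Cc1nn(-c2ncnc3nc[nH]c23)c2c1C(OCc1ccccc1C#N)CC(=O)N2`: 2-cyanophenyl in place of 2,4-dichlorophenyl on a saturated chain carbon bound to an oxygen on a saturated carbon. Without a direct precedent, compound 3 is expected to give a number near that of compound 2 or somewhat higher. The step expected for compound 3 is a 2.1-fold higher number from compound 2 to compound 3 (0.31 log units; beyond the scatter). The estimated value for compound 3 is 500 nM, expected between 150 nM and 2000 nM.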

Compound 3, half-maximal effective concentration: 127 nM
For compound 3 the middle estimate is 3.9-fold (0.60 log units) above the measured one; measured number below the stated range.
By their numbers in this assay, from the lowest: compounds 3 and 2 (each within the scatter of the next); then compound 1.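

In this assay, the position on a saturated chain carbon bound to an oxygen tolerates the exchange of 2,4-dichlorophenyl for 2-cyanophenyl: a 1.9-fold lower number from compound 2 to compound 3 (0.28 log units; within the scatter), so the two chlorines are not required for a number in this range. The exchange of (4-fluorophenyl)carbonyl for 2-cyanophenyl gives a 7.7-fold lower number from compound 1 to compound 3 (0.88 log units; beyond the scatter), which extends the earlier step from that group to a second aryl substituent. No available evidence explains either step. It remains open whether the nitrile contributes at all, since plain phenyl is not among these compounds. From the compounds shown here alone, how a carboxylic acid or amine on that ring, or a longer chain, would read also remains open.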